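A few compounds are considered here, and "the series" means these few. Any claim that something is new, unique, unknown or untested is made for them only; others in the source may bear on it.

Measured so far:
- compound 1, `C[C@@H](O)[C@H](NC(=O)CN(c1nc(Cl)nc2[nH]cnc12)C1CC1)C(=O)OCc1ccccc1` — in a functional assay on the whole organism (Tail, strain ICR) with Mus musculus as the target, in the tail flick test, with a stated time of 30 min, at a dose of 25 umol/kg by the oral route (on this read-out lower numbers stand for a weaker effect and higher numbers for a stronger effect at the one dose given), compound 1 gives 21.9%
- compound 2, `C[C@@H](O)[C@H](NC(=O)CN(c1nc(Cl)nc2[nH]cnc12)C1CC1)C(=O)O` — compound 2 gives 18.6%
- compound 3, `O=C(CN(c1ncnc2c1ncn2C1CCCCO1)C1CC1)N[C@@H](CO)C(=O)OCc1ccccc1` — compound 3 gives 27.8%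

Compound 1 holds the second highest of the three numbers; its nearest neighbour is compound 2, and the gap to compound 3 is also within the scatter, so the three measured compounds cannot be told apart on this read-out.

The compound to be measured next is compound 4, `CC(C)C[C@H](NC(=O)CN(c1nc(Cl)nc2[nH]cnc12)C1CC1)C(=O)OCc1ccccc1`. It differs from compound 1 in one place: isobutyl in place of 1-hydroxyethyl on a saturated chain carbon bound to an amide-type nitrogen and a carbonyl carbon.

Going by the values given here, only one measured step changes a single place, and it concerns a different part of the molecule: a number 3.3 percentage points lower from compound 1 to compound 2 (within the scatter). Among the compounds with values here, compound 3 differs from compound 1 in several places at once, so it offers no clean step. No measured step bears on the change from 1-hydroxyethyl to isobutyl; the data give no reason to expect a step beyond the scatter in this assay in either direction.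

The expected step is therefore a number 0.1 percentage points higher from compound 1 to compound 4 (within the scatter), and compound 4 is estimated at 22%, within 8% to 38%.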

Compound 4, a percentage reported as activity, at one dose (the size of the read-out at that dose, not a potency): 33.9%
Estimate against measurement, compound 4: 11.9 percentage points below; measured number inside the range.
By their numbers in this assay, from the lowest: compounds 2, 1, 3 and 4 (each within the scatter of the next, the first and the last beyond it).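

In this assay, the group on the saturated chain carbon bound to an amide-type nitrogen and a carbonyl carbon proves able to shift the read-out: isobutyl in place of 1-hydroxyethyl gives (a number 12 percentage points higher from compound 1 to compound 4 (beyond the scatter)), the first single change shown to lie beyond the scatter, whereas hydrogen in place of benzyl gave only (a number 3.3 percentage points lower from compound 1 to compound 2 (within the scatter)). The change takes away 1 hydrogen-bond donor, 1 hydrogen-bond acceptor and a defined stereocentre, and it adds a heavy atom, so several features change together and this one step cannot separate them. No measurement at hand explains the step.

Going by these compounds, it remains open how a methyl group or a chain ending in an amine would read out on this carbon. Whether isobutyl would give a similar step on compound 2 or on the core of compound 3 is also unknown.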